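This account rests on a few compounds, and the source may have more. Where it says the series, first, only, none or still open, it means among the compounds named here.

Compound 1 `Cc1ccc(/N=N/N(C)c2ccccc2)cc1`: > 100000 nM
Compound 2 `Clc1cccc(/N=N/N2CCCCC2)c1`: > 100000 nM
Compound 3 `CN(/N=N/c1ccccc1)c1ccccc1`: > 100000 nM

In an ADME assay on BHK-21 cells (Mesocricetus auratus) for cytotoxicity, read by MTT assay, with a stated time of 96 h (a lower number here means that less compound is tolerated, a higher number that more compound is tolerated), compound 3 stands at > 100000 nM, which is a limit of the assay and not a number. The whole set reads the same way: the limit of > 100000 nM in this assay, at which 3 of the 3 values shown sit.

Compound 4 `CN(/N=N/c1cccc([N+](=O)[O-])c1)c1ccccc1` differs from compound 3 in one place, with nitro in place of hydrogen on an aromatic carbon, meta to a large group: nitro in place of hydrogen on an aromatic carbon.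

Going by the values given here, the only measured step that bears on this change is a step that the two limits leave unreadable from compound 1 to compound 3, and it involves methyl, not nitro. With no readable size to build on, no shift beyond the scatter is expected in this assay.

The estimated step is a number no higher from compound 3 to compound 4 (the limit leaves the size open).

Compound 4 is expected at 100000 nM, with an estimated range of 40000 nM to 100000 nM.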

Compound 4, half-maximal cytotoxic concentration: > 100000 nM
Compound 4: only a limit was reported; the forecaster's own chance of this, stated with the estimate: 65%; the middle value sits exactly at the limit.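

Compound 3 and compound 4 both sit at a limit of this assay, so the size of the step between them cannot be read: the limit of > 100000 nM in this assay, at which 4 of the 4 values shown sit.

The compounds shown leave open how far past that limit each one lies, and which change to the shared core, if any, would give a readable value in this assay for cytotoxicity.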